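This account rests on a few compounds, and the source may have more. Where it says the series, first, only, none or still open, it means among the compounds named here.

Measured in a functional assay on HEK293 cells for agonist activity at D(4) dopamine receptor (Homo sapiens), read by FLIPR; a lower number here means a smaller maximal response, a higher number a larger maximal response:

compound 1 `COc1cccc(C)c1NC(=O)CN1CCC(c2cccc[n+]2[O-])CC1`: 56%
compound 2 `Cc1cccc(NC(=O)CN2CCC(c3ccc(O)cc3)CC2)c1`: 60%

Among the measured compounds shown here, compound 1 stands lowest of the two numbers so far, but its nearest neighbour, compound 2, lies only within the scatter of it, so no order between the two can be read. In this assay compound 1 gives 56% and compound 2 gives 60%; both compounds reach a maximal response near the middle of the control range.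

The next compound to be measured is compound 3 `COc1cccc(C)c1NC(=O)CN1CCC(c2ccccn2)CC1`. Its structure differs from compound 1 in one place: a group of 6 heavy atoms (5 carbon, 1 nitrogen; one six-membered aromatic ring with 1 hetero atom) in place of a group of 7 heavy atoms (5 carbon, 1 nitrogen, 1 oxygen; one six-membered aromatic ring with 1 hetero atom), on a saturated ring carbon. Pyridin-2-yl enters on a saturated ring carbon of the six-membered non-aromatic ring with one nitrogen, three ring bonds from the ring nitrogen. For the measured compounds named here, no pair of measured compounds shows a step of this kind, so no measured step can be carried over.

For compound 3 in this assay the step from compound 1 is expected to be small, a number 4 percentage points higher from compound 1 to compound 3 (within the scatter), with no direction beyond the scatter clearly favoured. The estimate for compound 3 is 60%, with a range from 40% to 80%.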

Compound 3, largest response reached (reported as efficacy), in percent of the reference or control that the assay uses: 69%
Compound 3: the middle estimate sits 9 percentage points below what was measured, and the stated range covers the measured number.
By their numbers in this assay, from the lowest: compounds 1, 2 and 3 (each within the scatter of the next, the first and the last beyond it).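

In this assay the saturated ring carbon three ring bonds from the ring nitrogen now has its first one-place step: pyridin-2-yl in place of the group of 7 heavy atoms gives a number 13 percentage points higher from compound 1 to compound 3 (beyond the scatter). The two groups share one six-membered aromatic ring with 1 hetero atom, the same counts of hydrogen-bond donors and acceptors and no net charge, and differ in their counts by the 1 oxygen atom, so a change this small at this position is enough to shift the maximal response modestly. No measurement available here bears on the reason for this shift.

This single step does not show whether the maximal response depends on where the ring nitrogen sits, which pyridin-3-yl, pyridin-4-yl or phenyl on the same ring carbon could test. It also leaves open whether the step holds with another group on the amide nitrogen, as compound 2 differs from compound 1 in more than one place and gives no such comparison.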